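Compound 2 to compound 4: hydroxy gives way to ethyl

This account rests on a few compounds, and the source may have more. Where it says the series, first, only, none or still open, it means among the compounds named here.

Compound 2 `O=C1O[C@H]([C@@H](O)Cn2cc(CCO)nn2)C(OCc2ccccc2)=C1OCc1ccccc1` was measured in an ADME assay on HFF cells (Homo sapiens) for cytotoxicity, read by MTT assay, with a stated time of 72 h (a higher number here means a weaker inhibitor, a lower number a stronger inhibitor), where compound 2 gives 58500 nM. That is the highest of the three numbers recorded so far. Compound 1 `Cc1ccc(S(=O)(=O)NCc2cn(C[C@H](O)[C@H]3OC(=O)C(OCc4ccccc4)=C3OCc3ccccc3)nn2)cc1` gives 50 nM in this assay, and compound 3 `CC(C)(C)OC(=O)N1CCN(C(=S)SCc2cn(C[C@H](O)[C@H]3OC(=O)C(OCc4ccccc4)=C3OCc3ccccc3)nn2)CC1` gives 60 nM, each far below compound 2. For the measured compounds named here, the one step measured at this site, a 1200-fold higher number from compound 1 to compound 2 (3.07 log units; beyond the scatter), shows how wide that separation is.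

Compound 4 `CCCCc1cn(C[C@H](O)[C@H]2OC(=O)C(OCc3ccccc3)=C2OCc2ccccc2)nn1` has not yet been measured. It differs from compound 2 by ethyl in place of hydroxy on a saturated chain carbon, two bonds along the chain from an aromatic carbon. Going by the values given here, only the step of a 1200-fold higher number from compound 1 to compound 2 (3.07 log units; beyond the scatter) bears on this position: there a large group left and a hydroxymethyl entered, and the number rose sharply. In compound 4 the hydroxy leaves and an ethyl enters, so the change runs the opposite way, although no measured pair tells how far a hydroxy alone accounts for the gap. Compound 1 and compound 3, the two with low numbers, both carry substituents on that chain without a hydroxy.

Compound 4 is therefore expected to give a lower number than compound 2, estimated at 5000 nM with a range from 500 nM to 30000 nM. The expected step of a 12-fold lower number from compound 2 to compound 4 (1.07 log units; beyond the scatter) should lie beyond the scatter yet fall well short of the step of a 1200-fold higher number from compound 1 to compound 2 (3.07 log units; beyond the scatter).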

Compound 4, half-maximal inhibitory concentration: 26300 nM
Beside the measured number, compound 4's estimate is 5.3-fold (0.72 log units) below it, within the range that was stated.
By their numbers in this assay, from the lowest: compounds 1 and 3 (each within the scatter of the next); then compound 4; then compound 2.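

In this assay the change from 2-hydroxyethyl to butyl gives only a 2.2-fold lower number from compound 2 to compound 4 (0.35 log units; beyond the scatter) and so separates the effect of the hydroxy from that of the larger change seen earlier. The step is modest, although it lies beyond the scatter, so the hydroxy on this saturated chain carbon, two bonds along the chain from an aromatic carbon, accounts for only a small part of the distance between compound 2 and compound 1. With the hydroxy gone the distance remains large, as a 530-fold higher number from compound 1 to compound 4 (2.72 log units; beyond the scatter) shows, and it is of the same order as a 1200-fold higher number from compound 1 to compound 2 (3.07 log units; beyond the scatter), so the low number of compound 1 goes with its ((4-methylphenyl)sulfonyl)amino group and not with the mere lack of a hydroxy.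

Still open, going by these compounds, is whether an amine, a carboxylic acid or a longer alkyl chain at this place would move the number further, and how much of the ((4-methylphenyl)sulfonyl)amino group is needed for the low number of compound 1. Nothing measured here explains why these steps have the sizes they do.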